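Swapping a hydroxyalkyl arm for a methylphenyl ring

A few compounds are considered here, and "the series" means these few. Any claim that something is new, unique, unknown or untested is made for them only; others in the source may bear on it.

In an assay on isolated protein for inhibition of myosin-2 (Bos taurus), read by spectrophotometry, with a stated time of 24 min (on this read-out higher numbers stand for weaker inhibition and lower numbers for stronger inhibition), compound 1 `C/C(=N\Nc1ccccc1)c1c(O)c2ccccc2oc1=O` gives 27000 nM and compound 2 `C/C(=N\CCCO)c1c(O)c2ccccc2oc1=O` gives 37000 nM, the higher of the two numbers, with the step of a 1.4-fold higher number from compound 1 to compound 2 (0.14 log units; within the scatter). Compound 3 `C/C(=N\Cc1ccc(C)cc1)c1c(O)c2ccccc2oc1=O` differs from compound 2 in one place: 4-methylphenyl in place of 2-hydroxyethyl on a saturated chain carbon bound to a double-bonded nitrogen. For the measured compounds named here, the only step measured so far, which traded an aromatic group for a hydroxy-bearing chain, stayed within the scatter, so the reverse kind of trade in this assay is expected to move the number little. Compound 3 is therefore estimated at 30000 nM, within 10000 nM to 90000 nM, a step of a 1.2-fold lower number from compound 2 to compound 3 (0.09 log units; within the scatter).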

Compound 3, half-maximal inhibitory concentration: 7900 nM
Compound 3: the middle estimate sits 3.8-fold (0.58 log units) above what was measured; the whole stated range lies above it.
By their numbers in this assay, from the lowest: compound 3; then compounds 1 and 2 (each within the scatter of the next).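

In this assay this position proves able to shift the reading: 4-methylphenyl in place of 2-hydroxyethyl on a saturated chain carbon bound to a double-bonded nitrogen gives a modest change beyond the scatter (a 4.7-fold lower number from compound 2 to compound 3 (0.67 log units; beyond the scatter)). For the compounds shown here, the only earlier step stayed within the scatter, so this is the first sign that the group here matters. Nothing measured explains the change.

On these data alone, whether the ring alone or its methyl goes with the lower number stays open. A plain phenyl would help separate the two, while a ring carrying an amine or a carboxylic acid would test how far this position tolerates change.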